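This account rests on a few compounds, and the source may have more. Where it says the series, first, only, none or still open, it means among the compounds named here.

Compound 1 `O=c1[nH]c(=O)n([C@@H]2O[C@H](CO)[C@@H](O)[C@H]2O)c(I)c1F`: > 50000 nM, a limit of the assay
Compound 2 `[N-]=[N+]=Nc1c(F)c(=O)[nH]c(=O)n1[C@@H]1O[C@H](CO)[C@@H](O)[C@H]1O`: 700 nM
Compound 3 `Nc1c(F)c(=O)[nH]c(=O)n1[C@@H]1O[C@H](CO)[C@@H](O)[C@H]1O`: 1300 nM

These three compounds were tested in a functional assay on OCI-Ly7 cells (Homo sapiens) for antiproliferative activity, read by WST assay, with a stated time of 3 days; on this read-out lower numbers stand for stronger inhibition and higher numbers for weaker inhibition. Compound 3 gives 1300 nM, the highest of the two true numbers, although its gap to its nearest neighbour is small: a 1.9-fold higher number from compound 2 to compound 3 (0.27 log units; within the scatter).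

The step followed here leads to compound 4 `CCc1c(F)c(=O)[nH]c(=O)n1[C@@H]1O[C@H](CO)[C@@H](O)[C@H]1O`, which has not yet been measured. The change is ethyl in place of amino on an aromatic carbon, with ethyl in place of amino on an aromatic carbon.

Among the compounds with values here, three measured steps concern this same carbon. Azido in place of iodo gave an at least 71-fold lower number from compound 1 to compound 2 (1.85 log units; beyond the scatter), and amino in place of iodo gave an at least 38-fold lower number from compound 1 to compound 3 (1.58 log units; beyond the scatter). Both are large, so the group at this carbon can move the number strongly. Amino in place of azido gave only a 1.9-fold higher number from compound 2 to compound 3 (0.27 log units; within the scatter).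

Within the data shown here, no measured compound carries an alkyl group here, so the size of the step is uncertain. Ethyl resembles neither azido nor amino in holding nitrogen, and the only compound without nitrogen at this carbon is compound 1, at > 50000 nM. A moderate to large move towards a higher number in this assay is therefore expected, though probably short of that limit.

That expectation amounts to an estimated 6.2-fold higher number from compound 3 to compound 4 (0.79 log units; beyond the scatter). Compound 4 is expected at about 8000 nM, with an estimated range of 1500 nM to 40000 nM.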

Compound 4, half-maximal inhibitory concentration: 1900 nM
Compound 4: the middle estimate sits 4.2-fold (0.62 log units) above what was measured, and the stated range covers the measured number.
By their numbers in this assay, from the lowest: compounds 2, 3 and 4 (each within the scatter of the next, the first and the last beyond it). At a limit, above all of these: compound 1.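

In this assay, the change from amino to ethyl gives a 1.5-fold higher number from compound 3 to compound 4 (0.16 log units; within the scatter), so a group holding no nitrogen and counting no hydrogen-bond donor or acceptor can take this place on the aromatic carbon without a change beyond the scatter. Set against azido, the same group gives a 2.7-fold higher number from compound 2 to compound 4 (0.43 log units; beyond the scatter), a modest step, so azido and ethyl are separated beyond the scatter even though amino lies within the scatter of each. From iodo, ethyl gives an at least 26-fold lower number from compound 1 to compound 4 (1.42 log units; beyond the scatter), so a group without nitrogen at this carbon does not by itself reach the value of the iodo compound, which is a limit and not a number: the limit of > 50000 nM in this assay, at which 1 of the 4 values shown sits.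

The compounds shown leave open whether a shorter or longer chain, such as methyl or propyl, or a branched one such as isopropyl, would stay level with ethyl, and whether chloro or bromo would stand with iodo. They also leave open whether a hydroxyl or a methoxy group at this carbon would fall with amino and ethyl in this assay.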